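The source may report more compounds than this note shows. Statements on the series, on what has been measured and on what is new or still open speak of the compounds shown alone.

In a functional assay on PC-3 cells (Homo sapiens) for cytotoxicity, read by MTT assay, with a stated time of 72 h (a higher number here means a weaker inhibitor, a lower number a stronger inhibitor), compound 3 `COc1ccc(Cn2ncc3cc(C(=N)Nc4ccc(N5CCN(C)CC5)cc4)ncc32)cc1` gives 6100 nM. This stands at the lowest of the two numbers recorded in this assay. Its nearest neighbour is compound 1 `COc1ccc(Cn2nc(-c3ccccc3)c3cc(C(=N)Nc4ccccc4)ncc32)cc1`, which in this assay gives 6300 nM; the two values lie within the scatter of each other, so no order between them can be read. Compound 2 `N=C(Nc1ccccc1)c1cc2cn[nH]c2cn1` belongs to the same series, but in this assay compound 2 gives "not determined" (no result reported), so no result is available for it.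

Compound 4 `COc1ccc(Cn2ncc3cc(C(=N)Nc4ccccc4)ncc32)cc1` differs from compound 3 in one place: hydrogen in place of 4-methylpiperazin-1-yl on an aromatic carbon. For the measured compounds named here, no step between two measured compounds maps onto this change, so its size must be guessed. Because compound 1, which also carries an unsubstituted phenyl on the amidine nitrogen, gives 6300 nM, the expected effect of the change from compound 3 to compound 4 is small, and the estimated step from compound 3 to compound 4 is a 1.1-fold higher number from compound 3 to compound 4 (0.06 log units; within the scatter), within the scatter or slightly toward a weaker inhibitor. Compound 4 is accordingly expected to give about 7000 nM, with a likely range from 2500 nM to 20000 nM.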

Compound 4, half-maximal inhibitory concentration: 36000 nM
Compound 4: middle estimate off by 5.1-fold (0.71 log units), on the low side, outside the stated range (above it).
By their numbers in this assay, from the lowest: compounds 3 and 1 (each within the scatter of the next); then compound 4.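

Hydrogen in place of 4-methylpiperazin-1-yl on an aromatic carbon brings a 5.9-fold higher number from compound 3 to compound 4 (0.77 log units; beyond the scatter) in this assay, so the group at this place matters to the read-out, a step the earlier compounds could not show. Hydrogen in place of phenyl at another aromatic carbon of the core brings a 5.7-fold higher number from compound 1 to compound 4 (0.76 log units; beyond the scatter) in this assay, so each of the two groups goes with a lower number than hydrogen at its own place. The compounds shown include no measurement that accounts for either step.

Going by these compounds, whether a morpholine ring, a dimethylamino group or a plain methyl on that aromatic carbon would match 4-methylpiperazin-1-yl remains open. So does the outcome of carrying phenyl and 4-methylpiperazin-1-yl together on the same core.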